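The source may report more compounds than this note shows. Statements on the series, on what has been measured and on what is new or still open speak of the compounds shown alone.

Compound 1, `O=C(O)c1ccccc1-c1ccc(CCc2ncc(CC3CCCCC3)[nH]2)cc1`, gives 41 nM in an in vitro functional assay on cells for agonist activity at Bombesin receptor subtype-3 (Homo sapiens), read by luminescence and calcium flux; a higher number here means that more compound is needed for the effect, a lower number that less compound is needed. Compound 2, `CC(C)(C)Cc1cnc(CCc2ccc(-c3ccccc3C(=O)O)cc2)[nH]1`, gives 106 nM. Compound 3, `N#Cc1cccc(Cc2cnc(CCc3ccc(-c4ccccc4C(=O)O)cc3)[nH]2)c1`, gives 812 nM.

Among these three numbers compound 3 stands highest, so it needs the most compound for the effect. The three measured steps all alter the same saturated chain carbon bound to an aromatic carbon: a 2.6-fold higher number from compound 1 to compound 2 (0.41 log units; beyond the scatter), a 20-fold higher number from compound 1 to compound 3 (1.30 log units; beyond the scatter), and a 7.7-fold higher number from compound 2 to compound 3 (0.88 log units; beyond the scatter). Compound 4, `Cc1ccc(Cc2cnc(CCc3ccc(-c4ccccc4C(=O)O)cc3)[nH]2)cc1`, is the next compound and awaits measurement. It differs from compound 3 by 4-methylphenyl in place of 3-cyanophenyl on a saturated chain carbon bound to an aromatic carbon. Every measured step changes this very position, so all three bear on the new step, and the two steps leading to compound 3 show that this position can move the number a long way. Going by the values given here, none of the measured steps exchanges one aromatic ring for another, so the direction rests on weaker ground. Compound 4 is expected to show a 2.7-fold lower number from compound 3 to compound 4 (0.43 log units; beyond the scatter) in this assay, a lower number than compound 3. Compound 4 is estimated at 300 nM, within a range from 80 nM to 1200 nM.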

Compound 4, half-maximal effective concentration: 2660 nM
For compound 4 the middle estimate is 8.9-fold (0.95 log units) below the measured one, outside the stated range (above it).
By their numbers in this assay, from the lowest: compound 1; then compound 2; then compound 3; then compound 4.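

Going by these compounds alone, exchanging one aromatic ring for another at this saturated chain carbon does change the result: 4-methylphenyl in place of 3-cyanophenyl gives a 3.3-fold higher number from compound 3 to compound 4 (0.52 log units; beyond the scatter) in this assay and is the first ring-for-ring step seen here. Both compounds with an aromatic ring now sit above those with a saturated group, with a 25-fold higher number from compound 2 to compound 4 (1.40 log units; beyond the scatter) when 4-methylphenyl replaces tert-butyl and a 65-fold higher number from compound 1 to compound 4 (1.81 log units; beyond the scatter) when it replaces cyclohexyl, the widest span seen at this position. Nothing available explains this order.

As far as these compounds go, the step swaps both the group on the ring, nitrile for methyl, and its place, so which of the two matters stays open, and a 3-methylphenyl or 4-cyanophenyl would separate them. Also open, from the compounds shown here alone, is how a longer saturated chain or a ring carrying an amine would compare at this carbon.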